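Cytotoxicity notes on the series: compound 1 toward compound 3

A few compounds are considered here, and "the series" means these few. Any claim that something is new, unique, unknown or untested is made for them only; others in the source may bear on it.

Measured so far:
compound 1 `O=C(N/N=C/c1ccccc1)c1cnccn1` — 100%
compound 2 `N#Cc1cccc(/C=N/NC(=O)c2cnccn2)c1` — 100%

In an ADME assay on J774 cells (Mus musculus) for cytotoxicity, read by MTT assay, with a stated time of 48 h, tested at 150 ug/mL (a lower number here means a stronger effect, a higher number a weaker effect of the compound at the concentration tested), compound 1 gives 100%, and compound 2 gives 100%. Compound 1 stands level with compound 2 at the digits shown; the only measured step, no change at the digits printed from compound 1 to compound 2 (within the scatter), brings cyano in place of hydrogen on an aromatic carbon and lies within the scatter.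

Compound 3 `CN(C)c1ccc(/C=N/NC(=O)c2cnccn2)cc1` is not yet measured. It differs from compound 1 by dimethylamino in place of hydrogen on an aromatic carbon. For the measured compounds named here, the one step that bears on this, no change at the digits printed from compound 1 to compound 2 (within the scatter), also exchanges hydrogen on an aromatic carbon of the same ring and produced no change beyond the scatter. On that basis no step beyond the scatter is expected for compound 3 in this assay, that is no change at the digits printed from compound 1 to compound 3 (within the scatter). Compound 3 is therefore estimated at 100%, within 85% to 105%.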

Compound 3, a percentage reported as activity, at one concentration (the size of the read-out at that concentration, not a potency): 89%
The estimate for compound 3 lay 11 percentage points above the measured number; the range from low to high includes it.
By their numbers in this assay, from the lowest: compound 3; then compounds 1 and 2 (each within the scatter of the next).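

In this assay, dimethylamino in place of hydrogen on an aromatic carbon, para to a large group, gives a number 11 percentage points lower from compound 1 to compound 3 (beyond the scatter), a modest step beyond the scatter. The earlier step on this ring, no change at the digits printed from compound 1 to compound 2 (within the scatter), showed no such movement, so a replacement of hydrogen on this ring is not always silent in this read-out. No measurement at hand accounts for the step to compound 3.

From the compounds shown here alone, it remains open whether the step belongs to dimethylamino alone or also appears with a primary amine, a methoxy group or a carboxylic acid at the same place. Going by these compounds, the read-out at a single concentration gives the size of the effect only, so how compound 3 would behave at other concentrations also stays open.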